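Demethylation step on a bis-arylidene cyclohexanone series

The source may report more compounds than this note shows. Statements on the series, on what has been measured and on what is new or still open speak of the compounds shown alone.

Measured compounds, with the read-out in a functional assay on SW-620 cells (Homo sapiens) for cytotoxicity, read by MTT assay, with a stated time of 72 h; on this read-out higher numbers stand for weaker inhibition and lower numbers for stronger inhibition:
- compound 1, `COc1cccc(/C=C2\CCC/C(=C\c3cccc(OC)c3OC)C2=O)c1`: 7000 nM
- compound 2, `COc1cccc(/C=C2\CCC/C(=C\c3cccc(O)c3)C2=O)c1OC`: 6400 nM
- compound 3, `COc1cc(/C=C2\CCC/C(=C\c3ccc(OC)c(OC)c3)C2=O)ccc1O`: 4500 nM

The three values sit close together; the gaps between compound 3 and compound 2 and between compound 3 and compound 1 are within the scatter, so no ordering among them is claimed.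

Compound 1 and compound 2 differ by hydrogen in place of methyl on an oxygen on an aromatic ring. The step that this change made is a 1.1-fold lower number from compound 1 to compound 2 (0.04 log units; within the scatter), which is within the scatter.

Compound 4, `COc1ccc(/C=C2\CCC/C(=C\c3ccc(O)c(O)c3)C2=O)cc1OC`, is not yet measured. It differs from compound 3 by hydrogen in place of methyl on an oxygen on an aromatic ring. The place of the change is the same as in the earlier pair, so it is the same change, though the ring that carries it reads differently one bond further out: there 3-methoxyphenyl to 3-hydroxyphenyl, here 4-hydroxy-3-methoxyphenyl to 3,4-dihydroxyphenyl. The difference between the core of compound 1 and the core of compound 3 is not broken down here.

For the measured compounds named here, the expectation for compound 4 rests on the one earlier instance of this change, which stayed within the scatter. The step from compound 3 to compound 4 is therefore expected to be small, about a 1.1-fold lower number from compound 3 to compound 4 (0.03 log units; within the scatter), because the earlier step was a 1.1-fold lower number from compound 1 to compound 2 (0.04 log units; within the scatter). Going by the values given here, with only one precedent on a differently substituted ring, the range is kept wide. For compound 4 in this assay the estimate is 4200 nM, between 1800 nM and 10000 nM.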

Compound 4, half-maximal inhibitory concentration: 10500 nM
Compound 4: the middle estimate sits 2.5-fold (0.40 log units) below what was measured, and the stated range ends below it.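

In this assay, hydrogen in place of methyl on an oxygen on an aromatic ring gives a 2.3-fold higher number from compound 3 to compound 4 (0.37 log units; beyond the scatter), a modest step in which 4-hydroxy-3-methoxyphenyl becomes 3,4-dihydroxyphenyl. Set beside the earlier instance of the same change, this step does not separate from it: the same change on two cores in this assay, a 1.1-fold lower number (0.04 log units; within the scatter) from compound 1 to compound 2 and a 2.3-fold higher number (0.37 log units; beyond the scatter) from compound 3 to compound 4, 2.6-fold (0.41 log units) apart, within the scatter of two such steps The two pairs therefore do not show that the core alters the outcome of this change, nor do they show that the outcome carries over unchanged from one core to another, so the step on the core of compound 3 stands as a single observation rather than a rule for the series.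

Still open, on these data alone, is whether the change would again stay within the scatter or give a higher number on a third core, and whether the higher number for compound 4 belongs to the 3,4-dihydroxyphenyl ring or depends on the rest of its structure. Also open, as far as these compounds go, is how an amine or a carboxylic acid in place of the hydroxy, or a longer chain in place of the methyl on that oxygen, would read in this assay.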